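Swapping Cyclohexyl for Benzyl on the Amide Nitrogen

This account rests on a few compounds, and the source may have more. Where it says the series, first, only, none or still open, it means among the compounds named here.

Compound 1 `COc1cc2c(cc1OC)C(CC(=O)N(C)C)CC2` and compound 2 `COc1cc2c(cc1OC)C(CC(=O)NC1CCCCC1)CC2` share one core and differ only at the amide. In a functional assay on the whole organism (strain Wistar) for inhibition, with Rattus norvegicus as the target, read by paw edema, with stated times of 60 min and 4 h, at a dose of 100 mg/kg by the oral route (a lower number here means less inhibition, a higher number more inhibition at the dose given (going by the name of the read-out)), compound 1 gives 35.9%, while compound 2 gives 50%, the higher of the two numbers, and the step of a number 14.1 percentage points higher from compound 1 to compound 2 (beyond the scatter) lies beyond the scatter. Compound 3 `COc1cc2c(cc1OC)C(CC(=O)NCc1ccccc1)CC2` carries benzyl in place of cyclohexyl on an amide-type nitrogen. Among the measured compounds shown here, only that one step bears on this change, and it tells of a larger amide substituent helping modestly; a benzyl keeps a similar size, so no step beyond the scatter is expected, a number 2 percentage points lower from compound 2 to compound 3 (within the scatter). Compound 3 is thus estimated at 48%, within 33% to 63%.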

Compound 3, a percentage reported as inhibition, in the whole organism at one dose (the size of the read-out at that dose, not a potency): 18.8%
Compound 3: middle estimate off by 29.2 percentage points, on the high side; the whole stated range lies above it.
By their numbers in this assay, from the lowest: compound 3; then compound 1; then compound 2.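

In this assay, this amide nitrogen proves more sensitive than the earlier pair suggested: benzyl, with its aromatic ring, in place of cyclohexyl, with its non-aromatic ring, gives a large drop (a number 31.2 percentage points lower from compound 2 to compound 3 (beyond the scatter)). Benzylamino also falls short of the smaller dimethylamino (a number 17.1 percentage points lower from compound 1 to compound 3 (beyond the scatter)), so among these three compounds, a larger group does not simply go with more inhibition. Nothing available explains the difference between these two rings.

Going by these compounds, what a phenylethyl group or a cyclopentyl ring would give on this nitrogen remains open.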